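The compounds below may be only part of what the source reports. "The series", "measured", "known", "first", "only" and "open" are said of these compounds alone.

Compound 1 `CCn1nc(CC(=O)Nc2ccc(OC(F)(F)F)c(Cl)c2)c2ccccc2c1=O` is the reference point here. In a functional assay on CHO cells for antagonist activity at sphingosine 1-phosphate receptor 2 (Homo sapiens), read by GTPgammaS binding (on this read-out higher numbers stand for weaker inhibition and lower numbers for stronger inhibition), compound 1 gives 473 nM, the highest of the three numbers in hand. Compound 2 `CCOc1cc2[nH]c(Cc3nn(CC(=O)O)c(=O)c4ccccc34)nc2cc1Cl`, which carries a carboxymethyl group on the aromatic nitrogen and a different right-hand part, gives 109 nM in this assay; compound 3 `O=C(O)Cn1nc(Cn2cc3cc(OCC4CC4)c(Cl)cc3n2)c2ccccc2c1=O`, built on the same idea, gives 53 nM. Both gaps to compound 1 lie beyond the scatter, so compound 1 is the weakest inhibitor among the three measured.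

Compound 4 `O=C(Cc1nn(C2CCNC2)c(=O)c2ccccc12)Nc1ccc(OC(F)(F)F)c(Cl)c1` keeps the amide side of compound 1 and changes only the substituent on the ring nitrogen: pyrrolidin-3-yl in place of ethyl on an aromatic nitrogen. Within the data shown here, no measured pair isolates this change, and compounds 2 and 3 differ from compound 1 in more than one place, so they give only a loose hint that a larger, polar group at this nitrogen is tolerated. The step from compound 1 to compound 4 is therefore expected to be small, a 1.6-fold lower number from compound 1 to compound 4 (0.20 log units; within the scatter), possibly within the scatter, with a slight lean toward stronger inhibition. For compound 4 the estimate in this assay is 300 nM, with a likely range from 80 nM to 1200 nM.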

Compound 4, half-maximal inhibitory concentration: 42 nM
Compound 4: the middle estimate sits 7.1-fold (0.85 log units) above what was measured; the whole stated range lies above it.
By their numbers in this assay, from the lowest: compounds 4 and 3 (each within the scatter of the next); then compound 2; then compound 1.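

Pyrrolidin-3-yl in place of ethyl on the aromatic nitrogen gives the first reading of this position with everything else held constant: in this assay, the change produces an 11-fold lower number from compound 1 to compound 4 (1.05 log units; beyond the scatter). With the amide side of compound 1 unchanged, this substituent alone is enough to move the number by a large step, so the position is sensitive to the group it carries. Nothing available on this pair accounts for the size of the step.

On these data alone, it remains open whether the step belongs to the ring or to its nitrogen: cyclopentyl, which has carbon in place of that nitrogen, and an open-chain 2-aminoethyl group would separate the two. Carboxymethyl on the amide side of compound 1 would also give a single-place reading of that group at this nitrogen.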